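The source may report more compounds than this note shows. Statements on the series, on what has been measured and on what is new or still open speak of the compounds shown alone.

Working notes on the thiosemicarbazone series. Four compounds belong here: compound 1 `CN(C)C(=S)N/N=C/c1cc2cccnc2s1`, compound 2 `FC(F)(F)c1ccccc1NC(=S)N/N=C/c1ccc2ccccc2n1`, compound 3 `S=C(NCc1ccccc1)N/N=C/c1ccc2ccccc2n1` and compound 4 `COc1ccc(NC(=S)N/N=C/c2ccc3ccccc3n2)cc1`, the last not yet measured. In a functional assay on HT-29 cells (Homo sapiens) for antiproliferative activity, read by sulforhodamine B assay, with a stated time of 72 h (on this read-out lower numbers stand for stronger inhibition and higher numbers for weaker inhibition), compound 1 gives 13400 nM, compound 2 gives 18100 nM and compound 3 gives 75700 nM. Compound 3 therefore stands at the highest number of the three; compound 2 is nearest and compound 1 furthest, and both gaps lie beyond the scatter. The step to compound 4 is the change (4-methoxyphenyl in place of benzyl on an amide-type nitrogen). Among the measured compounds shown here, no measured pair shows this exact change. Because compound 2, which also carries an aryl group on that nitrogen, gives 18100 nM, a moderate step down is expected, a 4.7-fold lower number from compound 3 to compound 4 (0.67 log units; beyond the scatter). Compound 4 is estimated at 16000 nM, within 5000 nM to 50000 nM.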

Compound 4, half-maximal inhibitory concentration: 82300 nM
Compound 4: the middle estimate sits 5.1-fold (0.71 log units) below what was measured; measured number outside the range, above it.
By their numbers in this assay, from the lowest: compounds 1 and 2 (each within the scatter of the next); then compounds 3 and 4 (each within the scatter of the next).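

In this assay the change of 4-methoxyphenyl in place of benzyl gives a 1.1-fold higher number from compound 3 to compound 4 (0.04 log units; within the scatter) on this amide-type nitrogen, so the two groups cannot be told apart at this position. Compound 2 at 18100 nM and compound 4 at 82300 nM both carry an aryl group here, so an aryl group alone does not bring the lower number of compound 2. No measurement available here accounts for this result.

Going by these compounds, what an unsubstituted phenyl or a 4-hydroxyphenyl would give on this nitrogen stays open. So does the effect of a small alkyl group such as methyl there.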